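Swapping the 4-fluorophenyl group of compound 2

This account rests on a few compounds, and the source may have more. Where it says the series, first, only, none or still open, it means among the compounds named here.

In a functional assay on A549 cells (Homo sapiens) for antiproliferative activity, read by sulforhodamine B assay, with a stated time of 48 h (on this read-out higher numbers stand for weaker inhibition and lower numbers for stronger inhibition), compound 1 (`COc1ccc(OC)c(/C=C/C(=O)/C=C(O)/C=C/c2cc(OC)ccc2OC)c1`) gives 16300 nM, whereas compound 2 (`COc1cccc(/C=C/C(=O)C(=Cc2ccc(F)cc2)C(=O)/C=C/c2cccc(OC)c2OC)c1OC`) gives 340 nM. Compound 2 thus holds the lower of the two numbers, a gap beyond the scatter. Compound 3 (`COc1cc(C=C(C(=O)/C=C/c2cccc(OC)c2OC)C(=O)/C=C/c2cccc(OC)c2OC)ccc1O`) differs from compound 2 as follows: 4-hydroxy-3-methoxyphenyl in place of 4-fluorophenyl on a double-bonded chain carbon bound to a double-bonded chain carbon. Among the measured compounds shown here, no measured pair isolates this change, so any forecast is uncertain. A modest weakening in this assay is expected, possibly not exceeding the scatter. The estimated change is a 1.8-fold higher number from compound 2 to compound 3 (0.25 log units; within the scatter). For compound 3 the expected value is 600 nM, with an estimated range from 150 nM to 2500 nM.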

Compound 3, half-maximal inhibitory concentration: 130 nM
Compound 3: the middle estimate sits 4.6-fold (0.66 log units) above what was measured; the measured number lies below the stated range.
By their numbers in this assay, from the lowest: compound 3; then compound 2; then compound 1.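

At the double-bonded chain carbon bound to a double-bonded chain carbon, the aryl group clearly matters: in this assay, 4-hydroxy-3-methoxyphenyl in place of 4-fluorophenyl gives a 2.6-fold lower number from compound 2 to compound 3 (0.42 log units; beyond the scatter). The change adds a hydrogen-bond donor and hydrogen-bond acceptors, and potency does not fall. Nothing in the data explains this gain.

The compounds shown do not separate the contribution of the hydroxyl from that of the methoxy group. Going by these compounds, how a plain phenyl, a 4-aminophenyl or a 4-carboxyphenyl group would behave at this place also remains open.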